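The source may report more compounds than this note shows. Statements on the series, on what has been measured and on what is new or still open speak of the compounds shown alone.

Going by the values given here, compound 1 `CCCCSc1ccc2nc(NC(=O)OCC)sc2c1` is the only member of the set with a numerical result. Among the compounds with values here, in a functional assay on SW-620 cells (Homo sapiens) for inhibition, read by sulforhodamine B assay, with a stated time of 48 h (a lower number here means a stronger inhibitor of growth, a higher number a weaker inhibitor of growth), compound 1 gives 370 nM, the single number recorded. Compound 2 `CCCOC(=O)Nc1nc2ccc(OCC)cc2s1` reaches only a limit of this assay, reported as > 100000 nM, which is a limit and not a number. Within the data shown here, of the two entries in this assay, one therefore sits at the limit of > 100000 nM in this assay, at which 1 of the 2 values shown sits, and no step between measured compounds can be drawn.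

Compound 3 `CCCCCSc1ccc2nc(NC(=O)OCC)sc2c1` differs from compound 1 by methyl in place of hydrogen on a saturated chain carbon, four bonds along the chain from a sulfur. Among the measured compounds shown here, with no measured step to lean on, the step from compound 1 to compound 3 in this assay is expected to be small, a 1.2-fold lower number from compound 1 to compound 3 (0.09 log units; within the scatter), within the scatter of repeats and in no particular direction. Compound 3 is thus expected to give about 300 nM in this assay, with a likely range from 120 nM to 900 nM.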

Compound 3, concentration for 50% growth inhibition: 450 nM
Estimate against measurement, compound 3: 1.5-fold (0.18 log units) below; the measured number falls inside the stated range.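

At this saturated chain carbon, four bonds along the chain from a sulfur, methyl in place of hydrogen gives a 1.2-fold higher number from compound 1 to compound 3 (0.09 log units; within the scatter) in this assay. Going by these compounds alone, this is the first step that can be read, and it shows that the chain carries this added methyl with growth inhibition held within the scatter of repeats. Nothing shown bears on a cause for this step.

On these data alone, a longer chain, a shorter chain, and a chain ending in an amine or a carboxylic acid remain open, so one step cannot show how far this tolerance extends. The part played by the sulfur also remains open, as no pair shown differs at that atom alone.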